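The source may hold more compounds than are shown below. What is called first, only, known or untested is meant among the compounds shown, and "the series" means these compounds.

Series notes. Compound 1 `N#Cc1cccc([C@]23CCC(N(CCN4CC[C@@H](O)C4)C(=O)Nc4cccc(Br)c4)CC2C3)c1` gives 34 nM in a functional assay for antagonist activity at melanin-concentrating hormone receptor 1 (Homo sapiens); on this read-out higher numbers stand for weaker inhibition and lower numbers for stronger inhibition. Compound 2 `N#Cc1cccc([C@]23CCC(N(CCN4CC[C@@H](O)C4)C(=O)Nc4cccc(Cl)c4)CC2C3)c1`, which carries chloro in place of bromo on an aromatic carbon, gives 27 nM in this assay; the step of a 1.3-fold lower number from compound 1 to compound 2 (0.10 log units; within the scatter). Compound 3 `CC(C)N(CCN(C(=O)Nc1cccc(Br)c1)C1CC[C@]2(c3cccc(C#N)c3)CC2C1)C(C)C`, with diisopropylamino in place of 3-hydroxypyrrolidin-1-yl on the chain, gives 5.7 nM; the step of a 6.0-fold lower number from compound 1 to compound 3 (0.78 log units; beyond the scatter). Compound 3 therefore holds the lowest number of the three, its steps to compound 2 and to compound 1 both beyond the scatter.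

Compound 4 `CC(C)N(CCN(C(=O)Nc1cc(F)cc(F)c1)C1CC[C@]2(c3cccc(C#N)c3)CC2C1)C(C)C` is not yet measured. It differs from compound 3 in one place: 3,5-difluorophenyl in place of 3-bromophenyl on an amide-type nitrogen. Among the measured compounds shown here, the only measured step that touches the same part of the molecule is the halogen exchange on that aromatic ring, a 1.3-fold lower number from compound 1 to compound 2 (0.10 log units; within the scatter), which stayed within the scatter. For the measured compounds named here, no measured pair places fluorine on that ring, and no pair exchanges bromo for fluoro, so the expectation rests on that single halogen swap alone. The expected step is a 1.4-fold higher number from compound 3 to compound 4 (0.15 log units; within the scatter), small and open in direction. Compound 4 is therefore estimated at 8 nM, with a range from 3 nM to 20 nM.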

Compound 4, inhibition constant: 4.5 nM
Compound 4: middle estimate off by 1.8-fold (0.25 log units), on the high side; measured number inside the range.
By their numbers in this assay, from the lowest: compounds 4 and 3 (each within the scatter of the next); then compounds 2 and 1 (each within the scatter of the next).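

The exchange of 3-bromophenyl for 3,5-difluorophenyl on the amide-type nitrogen gives, in this assay, a 1.3-fold lower number from compound 3 to compound 4 (0.10 log units; within the scatter), so this ring can lose its bromine and take two fluorines with no change that stands clear of the scatter. Until now, the only exchange on this ring was one halogen for another on the 3-hydroxypyrrolidin-1-yl side chain, a 1.3-fold lower number from compound 1 to compound 2 (0.10 log units; within the scatter); the second exchange alters the number of halogens, sits on the diisopropylamino side chain and also stays within the scatter, and neither ring exchange shown goes against that reading. No measurement at hand accounts for this flat response at the ring.

Still open, going by these compounds, is whether the ring needs a halogen at all: a plain phenyl, a 3-methoxyphenyl or a 3-(trifluoromethyl)phenyl on the amide-type nitrogen would test that. Also open, on these data alone, is whether 3,5-difluorophenyl gives the same result on the 3-hydroxypyrrolidin-1-yl side chain, which would show whether the ring and the amine can be varied independently.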